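The compounds below may be only part of what the source reports. "The series", "measured", "known", "first", "only" and "open" are said of these compounds alone.

Of the compounds shown here, three have been measured in an assay (Equus caballus) for inhibition of Thromboxane-A synthase (Homo sapiens), using microsomes; a higher number here means a weaker inhibitor, a lower number a stronger inhibitor. Compound 1 `C=C(C)C(CCC/C=C(\c1ccccc1)c1cccnc1)C(=O)O` gives 28 nM. Compound 2 `O=C(O)CCCC/C=C(/c1ccc(Br)cc1)c1cccnc1` gives 82 nM, and compound 3 `O=C(O)CCCC/C=C(/CCCc1ccccc1)c1cccnc1` gives 65 nM. Compound 2 lies beyond the scatter from compound 1, whose number is the lower one, whereas the numbers of compound 2 and compound 3 fall within the scatter of each other. Compound 4 `Cc1ccc(/C(=C/CCCCC(=O)O)c2cccnc2)cc1` has not yet been measured in this assay. It differs from compound 2 by methyl in place of bromo on an aromatic carbon. Among the measured compounds shown here, no measured pair shows this exchange, so no step can be drawn on. The exchange is expected to shift the number only modestly, likely within or just beyond the scatter, so the step of a 1.4-fold lower number from compound 2 to compound 4 (0.14 log units; within the scatter) is expected to be small. Compound 4 is therefore estimated at 60 nM, with a range from 25 nM to 150 nM.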

Compound 4, half-maximal inhibitory concentration: 85 nM
Beside the measured number, compound 4's estimate is 1.4-fold (0.15 log units) below it, within the range that was stated.
By their numbers in this assay, from the lowest: compound 1; then compounds 3, 2 and 4 (each within the scatter of the next).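

In this assay, among the compounds shown here, the change from 4-bromophenyl to 4-methylphenyl gives a 1.0-fold higher number from compound 2 to compound 4 (0.02 log units; within the scatter), the first step available between compounds that differ in one place. On this aromatic carbon, para to a large group, bromo and methyl therefore cannot be told apart by this read-out. Nothing at hand explains this result. From the compounds shown here alone, whether a methoxy group, an amine or a carboxylic acid at this place would also stay within the scatter of compound 2 remains open.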